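Permeability notes: trifluoromethyl removal in the quinoline-amine series

This account rests on a few compounds, and the source may have more. Where it says the series, first, only, none or still open, it means among the compounds named here.

Measured so far in an ADME assay for permeability, using PAMPA, with a stated time of 30 min, at pH 7.4; a higher number here means that the compound crosses the layer faster, a lower number that the compound crosses the layer more slowly:
compound 1, `COc1ccc(F)cc1CNCCCNc1ccnc2cc(C3CCCCC3)ccc12`, gives 23 10^-6 cm/s;
compound 2, `COc1cccc(CNCCCNc2ccnc3cc(Cc4ccccc4)ccc23)c1O`, gives 23 10^-6 cm/s;
compound 3, `COc1cccc(CNCCCNc2ccnc3cc(-c4ccc(C(F)(F)F)cc4)ccc23)c1O`, gives 237 10^-6 cm/s.

Compound 3 holds the highest number of the three. Its gap to compound 1 and to compound 2 is the same, and in both cases lies beyond the scatter; compound 1 and compound 2 themselves sit at the same number.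

Compound 4, `COc1cccc(CNCCCNc2ccnc3cc(-c4ccccc4)ccc23)c1O`, is not yet measured. It differs from compound 3 in one place: hydrogen in place of trifluoromethyl on an aromatic carbon.

Among the compounds with values here, only one measured step is available, a 10-fold higher number from compound 2 to compound 3 (1.01 log units; beyond the scatter). That step bundles two alterations at once, benzyl to an attached phenyl and the arrival of trifluoromethyl on that phenyl, so it does not isolate the part now being undone. Compound 1 and compound 3 differ in more than one place, so their numbers give no clean guide either. Within the data shown here, what the data show is that the one compound carrying trifluoromethyl stands well above the two that lack it.

On that basis a drop in this assay is expected for compound 4, smaller than the full step seen before. For compound 4 the expected step is a 2.4-fold lower number from compound 3 to compound 4 (0.37 log units; beyond the scatter). The estimate for compound 4 is 100 10^-6 cm/s, with a range from 40 10^-6 cm/s to 250 10^-6 cm/s.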

Compound 4, apparent permeability: 237 10^-6 cm/s
For compound 4 the middle estimate is 2.4-fold (0.37 log units) below the measured one; measured number inside the range.
By their numbers in this assay, from the lowest: compounds 1 and 2 (each within the scatter of the next); then compounds 3 and 4 (each within the scatter of the next).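

In this assay, hydrogen in place of trifluoromethyl on this aromatic carbon, para to a large group, gives no change at the digits printed from compound 3 to compound 4 (within the scatter), so the trifluoromethyl group accounts for none of the earlier gap between the two compounds. The earlier step bundled two alterations, and the gap now sits with the other one, phenyl in place of benzyl, which gives a 10-fold higher number from compound 2 to compound 4 (1.01 log units; beyond the scatter). The series thus shows that, with the rest of the structure held constant, the number responds to the group attached to the shared core and not to this substituent on the phenyl ring, though no measurement at hand gives a cause for either step.

Hydrogen and trifluoromethyl are the only two groups shown at this position, so it remains open whether an amine or a carboxylic acid on the same carbon would leave the number equally unchanged. Going by these compounds, it is also open how a longer chain in place of the benzyl link would read, and whether the step from benzyl to phenyl holds on other amine side chains, such as that of compound 1.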